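The compounds below may be only part of what the source reports. "The series", "measured", "known", "first", "only" and "open" are said of these compounds alone.

Working notes on the series.

Compound 1 `NCCCCn1c(SCCc2c[nH]c3ccccc23)nnc1-c1cnc2ccccc2n1` is the reference point. Among the compounds with values here, in an assay on isolated protein for inhibition of somatostatin receptor type 2 (Homo sapiens), tested at 10 uM (a higher number here means a weaker inhibitor, a lower number a stronger inhibitor), compound 1 gives 32 nM, the lower of the two numbers measured so far. Within the data shown here, compound 2 `NCCCn1c(SCCc2c[nH]c3ccccc23)nnc1-c1ccc2ccccc2c1` differs from it in two places at once, so no single step connects them; in this assay compound 2 gives 640 nM, a much higher number, beyond the scatter of compound 1.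

Compound 3 `NCCCCn1c(SCCc2c[nH]c3ccccc23)nnc1-c1cc2ccccc2s1` has not been measured. It carries the change (1-benzothiophen-2-yl in place of quinoxalin-2-yl on an aromatic carbon), that is, 1-benzothiophen-2-yl in place of quinoxalin-2-yl on an aromatic carbon, with the 4-aminobutyl group kept. Among the measured compounds shown here, no measured pair isolates this change. Compound 2 shows that a bicyclic group without ring nitrogen can go with a weaker number, though its shorter chain clouds the reading. The step from compound 1 to compound 3 is expected to be modest and upward, a 3.1-fold higher number from compound 1 to compound 3 (0.49 log units; beyond the scatter). For compound 3 the expected value in this assay is 100 nM, within 30 nM to 400 nM.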

Compound 3, inhibition constant: 160 nM
Compound 3: middle estimate off by 1.6-fold (0.20 log units), on the low side; measured number inside the range.
By their numbers in this assay, from the lowest: compound 1; then compound 3; then compound 2.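

Within the data shown here, with the 4-aminobutyl group kept, this is the first single change read at this position: in this assay, 1-benzothiophen-2-yl in place of quinoxalin-2-yl gives a weaker inhibitor (a 5.0-fold higher number from compound 1 to compound 3 (0.70 log units; beyond the scatter)). The comparison of compound 1 with compound 2 could not show this, since those two differ in two places at once; the aryl change alone now has a measured size, and the step is beyond the scatter. No measurement at hand explains the step.

The compounds shown leave open whether the step follows the loss of ring nitrogen or the entry of sulfur, a question that a quinolin-2-yl or 1-benzofuran-2-yl group on the same carbon would address. They also leave open the separate contribution of the chain, which a 3-aminopropyl group paired with quinoxalin-2-yl would isolate.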